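The source may report more compounds than this note shows. Statements on the series, on what has been measured and on what is new or still open speak of the compounds shown alone.

Measured in an ADME assay (liver, Mus musculus) for metabolic stability, using microsomes; a higher number here means that the compound lasts longer, a lower number that the compound disappears faster:
- Compound 1 `CCCc1nc2ccccn2c1C(=O)NCc1ccc(-c2ccccc2)cc1`: 0.145 h
- Compound 2 `CCc1nc2ccc(Cl)cn2c1C(=O)NCc1ccc(-c2ccc(C#N)cc2)cc1`: > 1 h
- Compound 3 `CCc1nc2cc(Cl)ccn2c1C(=O)NCc1ccc(N2CCCCC2)cc1`: 0.0383 h

The entry for compound 2, > 1 h, is a limit of the assay and not a number. Of the two true numbers, compound 3 has the lower at 0.0383 h, and compound 1 lies higher at 0.145 h, a gap beyond the scatter.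

Compound 4 `CCc1nc2cc(Cl)ccn2c1C(=O)NCc1ccc(N2CC3CCCCC3C2)cc1` differs from compound 3 in one place, on an aromatic carbon of a six-membered aromatic ring of carbon only: a group of 9 heavy atoms (8 carbon, 1 nitrogen; one five-membered non-aromatic ring with 1 hetero atom, one six-membered non-aromatic ring of carbon only) in place of a group of 6 heavy atoms (5 carbon, 1 nitrogen; one six-membered non-aromatic ring with 1 hetero atom), on an aromatic carbon. Among the compounds with values here, no measured pair shows a change of this kind. Only a small step is therefore expected, staying within the scatter, and the estimated change is a 1.3-fold lower number from compound 3 to compound 4 (0.11 log units; within the scatter). For compound 4 the estimated half-life in this assay is 0.03 h, with an expected range of 0.012 h to 0.08 h.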

Compound 4, half-life: 0.105 h
Estimate against measurement, compound 4: 3.5-fold (0.54 log units) below, outside the stated range (above it).
By their numbers in this assay, from the lowest: compound 3; then compounds 4 and 1 (each within the scatter of the next). At a limit, above all of these: compound 2.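

In this assay, the aromatic carbon para to a large group proves sensitive to what it carries: the group of 9 heavy atoms, with its five-membered and six-membered non-aromatic rings, in place of piperidin-1-yl gives a 2.7-fold higher number from compound 3 to compound 4 (0.44 log units; beyond the scatter). A single change at this place is thus enough to move the half-life beyond the scatter. Nothing in the data shown accounts for this step.

As far as these compounds go, whether the second ring or simply the larger group matters remains open. So does the effect of a morpholine ring or a dimethylamino group at this place.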